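A few compounds are considered here, and "the series" means these few. Any claim that something is new, unique, unknown or untested is made for them only; others in the source may bear on it.

Measured compounds:
compound 1 `C#Cc1cccc(Nc2ncnc3cc(NC(=O)/C=C/c4ccccc4)sc23)c1` gives 26200 nM
compound 2 `O=C(/C=C/c1ccc(O)cc1)Nc1cc2c(Nc3ccc(Cl)c(Cl)c3)ncnc2s1` gives 34300 nM
compound 3 `O=C(/C=C/c1ccccc1)Nc1cc2c(Nc3ccc(Cl)c(Cl)c3)ncnc2s1` gives 7600 nM

All three numbers come from a functional assay on A549 cells (Homo sapiens) for antiproliferative activity, read by MTT assay, with a stated time of 48 h; a higher number here means a weaker inhibitor, a lower number a stronger inhibitor. Compound 1 stands second highest of the three: compound 2 lies within the scatter of it, while compound 3 lies beyond the scatter and lower.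

Compound 4 `O=C(/C=C/c1ccccc1)Nc1cc2ncnc(Nc3ccc(F)c(Cl)c3)c2s1` arises from compound 1 by a single change: 3-chloro-4-fluorophenyl in place of 3-ethynylphenyl on a nitrogen on an aromatic ring. For the measured compounds named here, the one measured step, a 4.5-fold lower number from compound 2 to compound 3 (0.65 log units; beyond the scatter), concerns a hydroxy group elsewhere in the molecule, so it does not bear directly on this change. Compound 1 and compound 3 also differ only at this same nitrogen, and compound 3 gives the lower number, beyond the scatter. That is the only hint available, and it points toward a lower number for compound 4 than for compound 1, though the entering group here is not that of compound 3, so the expectation is held loosely.

Compound 4 is therefore expected to give 11000 nM, with a range from 4000 nM to 30000 nM. The expected step is a 2.4-fold lower number from compound 1 to compound 4 (0.38 log units; beyond the scatter).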

Compound 4, half-maximal inhibitory concentration: 6670 nM
Compound 4: middle estimate off by 1.6-fold (0.22 log units), on the high side, and the stated range covers the measured number.
By their numbers in this assay, from the lowest: compounds 4 and 3 (each within the scatter of the next); then compounds 1 and 2 (each within the scatter of the next).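

In this assay, for the compounds shown here, replacing 3-ethynylphenyl with 3-chloro-4-fluorophenyl on the nitrogen gives a 3.9-fold lower number from compound 1 to compound 4 (0.59 log units; beyond the scatter), the first direct reading of a change at this position. The two groups have the same count of heavy atoms, and each has one six-membered aromatic ring of carbon only and no hydrogen-bond donors or acceptors, so these counts do not separate them; what differs is a triple bond on one side and a chlorine and a fluorine on the other. Nothing available explains why this swap lowers the number.

A single step cannot show whether the chlorine, the fluorine or the loss of the triple bond matters most. It also leaves open how a 3-chlorophenyl, a 4-fluorophenyl or a methoxy-bearing phenyl group would read on this nitrogen.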